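The compounds below may be only part of what the source reports. "The series", "measured", "known", "first", "only" and "open" are said of these compounds alone.

Measured so far:
compound 1, `CCCCc1ccc(-c2cc(=O)c3c(o2)C(CC)(CC)C(=O)C(CC)=C3O)cc1`, 37 uM in a functional assay on KBVIN cells (Homo sapiens) for antiproliferative activity, read by sulforhodamine B assay, with a stated time of 3 days; a higher number here means that more compound is needed for the effect, a lower number that less compound is needed
compound 2, `CCC1=C(O)c2c(oc(-c3ccc(SC)cc3)cc2=O)C(CC)(CC)C1=O`, 1.38 uM in this assay

Compound 2 stands at the lowest of the two numbers shown; its nearest neighbour is compound 1, and the two differ by the single replacement already measured: a 27-fold lower number from compound 1 to compound 2 (1.43 log units; beyond the scatter), methylsulfanyl in place of butyl on an aromatic carbon. That step is large and beyond the scatter.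

Compound 3, `CCC1=C(O)c2c(oc(-c3ccc(C)cc3C)cc2=O)C(CC)(CC)C1=O`, has not yet been measured in this assay. It differs from compound 2 as follows: 2,4-dimethylphenyl in place of 4-(methylsulfanyl)phenyl on an aromatic carbon. Going by the values given here, no measured step covers this exchange directly; the one step available, from compound 1 to compound 2, swaps a butyl for a methylsulfanyl, and it shows only that this aromatic substituent pattern can move the number a great deal. Since compound 3 gives up the methylsulfanyl that sits in compound 2 and carries two methyl groups on the ring instead, the estimate leans toward a higher number than compound 2 gives, though short of compound 1. Compound 3 is therefore expected at 8 uM, in the range 2 uM to 30 uM, which means an expected step of a 5.8-fold higher number from compound 2 to compound 3 (0.76 log units; beyond the scatter).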

Compound 3, concentration for half-maximal effect: 8.52 uM
Compound 3: the middle estimate sits 1.1-fold (0.03 log units) below what was measured; the measured number falls inside the stated range.
By their numbers in this assay, from the lowest: compound 2; then compound 3; then compound 1.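

In this assay, the exchange on this aromatic carbon next to the ring oxygen gives a 6.2-fold higher number from compound 2 to compound 3 (0.79 log units; beyond the scatter), which shows that the number of compound 2 is not kept when one aryl group is replaced by another of the same size, with 8 heavy atoms in each. The earlier step, a 27-fold lower number from compound 1 to compound 2 (1.43 log units; beyond the scatter), had shown only that a butyl and a methylsulfanyl on the phenyl ring can lie far apart, whereas compound 3, at 8.52 uM, now places a ring with two methyl groups and no sulfur between compound 2, at 1.38 uM, and compound 1, at 37 uM. No measurement at hand bears on what lies behind this step.

The exchange removes the methylsulfanyl and brings in two methyl groups at once, so the compounds shown do not separate the loss of the sulfur from the gain of either methyl group. A single methyl group, a methoxy group or an amine on the phenyl ring would each test a different part of this change, and the three compounds shown say nothing about how any of these would read.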